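From compound 2 to compound 4: an untested change

The source may hold more compounds than are shown below. What is called first, only, known or untested is meant among the compounds shown, and "the series" means these compounds.

Compound 1 `O=c1c(-c2nnc(-c3ccc(Cl)cc3)o2)c[nH]c2ncc(-c3cccnc3)cc12` gives 20.1% in a functional assay on HCT-116 cells (Homo sapiens) for positive allosteric modulation, read by MTT assay, with stated times of 24 h and 48 h, tested at 2.5 uM; a higher number here means more inhibition of growth at the concentration tested, a lower number less inhibition of growth.
Compound 2 `CS(=O)(=O)c1ccc(-c2cnc3[nH]cc(-c4nnc(-c5ccc(Cl)cc5)o4)c(=O)c3c2)cc1` gives 24.9%.
Compound 3 `O=c1c(-c2nnc(-c3ccc(Cl)cc3)o2)c[nH]c2ncc(-c3ccccc3)cc12` gives 29.8%.

Compound 2 stands second highest of these three numbers; its nearest neighbour is compound 1, with a number 4.8 percentage points higher from compound 1 to compound 2 (within the scatter), and its furthest is compound 3, with a number 4.9 percentage points higher from compound 2 to compound 3 (within the scatter). Both gaps lie within the scatter, so the three compounds cannot be told apart in this assay.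

Compound 4 `CS(=O)(=O)c1ccc(-c2cnc3[nH]cc(-c4nnc(-c5ccccn5)o4)c(=O)c3c2)cc1` differs from compound 2 in one place: pyridin-2-yl in place of 4-chlorophenyl on an aromatic carbon. Within the data shown here, none of the measured steps touches this part of the molecule; a number 4.8 percentage points higher from compound 1 to compound 2 (within the scatter), a number 9.7 percentage points higher from compound 1 to compound 3 (within the scatter) and a number 4.9 percentage points higher from compound 2 to compound 3 (within the scatter) all alter the group on the other side of the shared core, and all stayed within the scatter. Among the measured compounds shown here, no measured step therefore bears directly on this change, and the only guide is that every alteration seen so far left this assay essentially unchanged.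

The expected step is a number 3.9 percentage points lower from compound 2 to compound 4 (within the scatter), with no direction beyond the scatter foreseen.

Compound 4 is estimated at 21%, with a range from 6% to 36%.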

Compound 4, percent growth inhibition at one concentration: 34.3%
Estimate against measurement, compound 4: 13.3 percentage points below, and the stated range covers the measured number.
By their numbers in this assay, from the lowest: compounds 1, 2, 3 and 4 (each within the scatter of the next, the first and the last beyond it).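

This is the first step shown at the carbon of the five-membered aromatic ring, which bears 4-chlorophenyl in compound 2. In this assay, the exchange for pyridin-2-yl gives a number 9.4 percentage points higher from compound 2 to compound 4 (within the scatter), so this change, like those on the other side of the shared core, stays within the scatter. No evidence is available that would account for this step.

The compounds shown leave open whether a piperidine or a carboxylic acid on this carbon would give a step beyond the scatter. On these data alone, whether pyridin-2-yl gives the same step alongside other groups on the far side of the core also remains open.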